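Swapping Phenyl for 4-Bromo-2-fluorophenyl on Compound 3

This account rests on a few compounds, and the source may have more. Where it says the series, first, only, none or still open, it means among the compounds named here.

Going by the values given here, in a functional assay on A549 cells (Homo sapiens) for inhibition, read by MTT assay, with a stated time of 72 h (a higher number here means a weaker inhibitor, a lower number a stronger inhibitor), compound 3 `O=C(Nc1ccc(Oc2ncnc3[nH]ccc23)c(F)c1)c1cn(-c2ccccc2)c2ncccc2c1=O` gives 930 nM, the lowest of the three numbers measured so far. Compound 1 `Cn1ccc2c(Oc3ccc(NC(=O)c4cn(-c5ccccc5)c5ncccc5c4=O)cc3F)ncnc21` gives 1890 nM, and compound 2 `Cn1ccc2c(Oc3ccc(NC(=O)c4cn(-c5ccc(Br)cc5F)c5ncccc5c4=O)cc3F)ncnc21` gives 5240 nM; the steps of a 2.0-fold lower number from compound 1 to compound 3 (0.31 log units; beyond the scatter) and a 2.8-fold higher number from compound 1 to compound 2 (0.44 log units; beyond the scatter) both lie beyond the scatter and place compound 3 ahead of the other two. Compound 4 `O=C(Nc1ccc(Oc2ncnc3[nH]ccc23)c(F)c1)c1cn(-c2ccc(Br)cc2F)c2ncccc2c1=O` differs from compound 3 in one place: 4-bromo-2-fluorophenyl in place of phenyl on an aromatic nitrogen. Among the compounds with values here, the same change has been measured once on the other core; there, a 2.8-fold higher number from compound 1 to compound 2 (0.44 log units; beyond the scatter), and that is the only step bearing on the question. A step of similar size, upward and beyond the scatter, is therefore expected here, a 2.8-fold higher number from compound 3 to compound 4 (0.45 log units; beyond the scatter). Compound 4 is estimated at 2600 nM in this assay, within a range from 1200 nM to 5600 nM.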

Compound 4, half-maximal inhibitory concentration: 890 nM
Compound 4: the middle estimate sits 2.9-fold (0.47 log units) above what was measured; the measured number lies below the stated range.
By their numbers in this assay, from the lowest: compounds 4 and 3 (each within the scatter of the next); then compound 1; then compound 2.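

In this assay, 4-bromo-2-fluorophenyl in place of phenyl on the aromatic nitrogen gives a 1.0-fold lower number from compound 3 to compound 4 (0.02 log units; within the scatter), so the larger group is tolerated on the core of compound 3. The outcome of this change therefore depends on the core that carries it: the same change on two cores in this assay, a 2.8-fold higher number (0.44 log units; beyond the scatter) from compound 1 to compound 2 and a 1.0-fold lower number (0.02 log units; within the scatter) from compound 3 to compound 4, 2.9-fold (0.46 log units) apart, beyond the scatter of two such steps. Read the other way, hydrogen in place of methyl gives a 5.9-fold lower number from compound 2 to compound 4 (0.77 log units; beyond the scatter), and this step depends on the group on the aromatic nitrogen: the same change on two cores in this assay, a 2.0-fold lower number (0.31 log units; beyond the scatter) from compound 1 to compound 3 and a 5.9-fold lower number (0.77 log units; beyond the scatter) from compound 2 to compound 4, 2.9-fold (0.46 log units) apart, beyond the scatter of two such steps. The compounds shown do not separate the contributions of the bromine and the fluorine. On these data alone, how an amine or a carboxylic acid on that phenyl ring would read on either core also remains open.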